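The source may hold more compounds than are shown below. What is called first, only, known or untested is meant among the compounds shown, and "the series" means these compounds.

Measured so far:
Compound 1, `CC(C)(C)OC(=O)N[C@@H](Cn1cc(CN2CCN(c3cccc4[nH]c(-c5ccc(C(C)(C)C)cc5)nc34)CC2)nn1)C(=O)O`, gives 10000 nM in a functional assay on cells for antagonist activity at Gonadotropin-releasing hormone receptor (Homo sapiens), read by FLIPR and calcium flux, with a stated time of 15 min; on this read-out lower numbers stand for stronger inhibition and higher numbers for weaker inhibition.
Compound 2, `CC(=O)N[C@H]1[C@H](O)[C@@H](O)[C@H](CO)O[C@H]1n1cc(CN2CCN(c3cccc4[nH]c(-c5ccc(C(C)(C)C)cc5)nc34)CC2)nn1`, gives > 10000 nM in this assay, which is a limit of the assay and not a number.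
Compound 3, `CC(C)(C)c1ccc(-c2nc3c(N4CCN(Cc5cn([C@@H]6O[C@H](CO)[C@@H](O)[C@H](O)[C@H]6O)nn5)CC4)cccc3[nH]2)cc1`, gives > 10000 nM in this assay, again a limit of the assay rather than a number.

Compound 3 therefore stands at the edge of what can be reported: the limit of > 10000 nM in this assay, at which 2 of the 3 values shown sit. The next compound, compound 4, `CC(C)(C)c1ccc(-c2nc3c(N4CCN(Cc5cn(-c6ccc(F)cc6)nn5)CC4)cccc3[nH]2)cc1`, has not yet been measured. It differs from compound 3 in one place: 4-fluorophenyl in place of 3,4,5-trihydroxy-6-(hydroxymethyl)oxan-2-yl on an aromatic nitrogen. A 4-fluorophenyl group thus takes the place of the 3,4,5-trihydroxy-6-(hydroxymethyl)oxan-2-yl group on an aromatic nitrogen. For the measured compounds named here, no measured pair shows this kind of exchange, and none of the three measured compounds carries 4-fluorophenyl, so nothing seen so far shows what that group does. Since compound 3 sits at a limit, any real number for compound 4 would be a move toward stronger inhibition; the step is expected to be an at least 10-fold lower number from compound 3 to compound 4 (1.00 log units; beyond the scatter), in that direction, though a second limit is also possible. Compound 4 is expected to come in at about 1000 nM, somewhere between 100 nM and 10000 nM.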

Compound 4, half-maximal inhibitory concentration: 20000 nM
Compound 4: middle estimate off by 20-fold (1.30 log units), on the low side; measured number above the stated range.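

For the compounds shown here, no step from compound 3 to compound 4 can be read, because compound 3 has only a limit of the assay and not a number: the limit of > 10000 nM in this assay, at which 2 of the 4 values shown sit.

The compounds shown leave open whether any group on the aromatic nitrogen gives strong inhibition.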